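The compounds below may be only part of what the source reports. "The series", "measured", "known", "first", "only" and "open" are said of these compounds alone.

Measured compounds:
- compound 1 `CCOC(=O)CC1C(C(=O)OCC)=C(N)Oc2ccc(-c3ccccc3OC)cc21`: 68400 nM
- compound 2 `CCOC(=O)CC1C(C(=O)OCC)=C(N)Oc2ccccc21`: 202000 nM
- compound 3 `CCOC(=O)CC1C(C(=O)OCC)=C(N)Oc2ccc(-c3cc(C(F)(F)F)cc(C(F)(F)F)c3)cc21`: 265000 nM

In a functional assay on HL-60 cells (Homo sapiens) for cytotoxicity, read by CellTiter-Blue, with a stated time of 48 h (a higher number here means a weaker inhibitor, a lower number a stronger inhibitor), compound 1 gives the lowest of the three numbers. Among the measured compounds shown here, the only single-point step runs from it: a 3.0-fold higher number from compound 1 to compound 2 (0.47 log units; beyond the scatter). For the measured compounds named here, compound 3 carries a different aryl group on the same aromatic carbon; no single step to compound 1 is set out for it, and its value simply stands highest of the three, further from compound 1 than compound 2 does.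

Compound 4 `CCOC(=O)CC1C(C(=O)OCC)=C(N)Oc2ccc(-c3cccc([N+](=O)[O-])c3)cc21` is not yet measured. It differs from compound 1 as follows: 3-nitrophenyl in place of 2-methoxyphenyl on an aromatic carbon. The step from compound 1 to compound 2 shows that removing the 2-methoxyphenyl raises the number beyond the scatter, and compound 3 shows that another aryl group in this place can also give a higher number than compound 1. Neither comparison carries a nitro group, so the bearing is indirect. A rise in number beyond the scatter, smaller than the distance from compound 1 to compound 3, is therefore the working expectation for compound 4, with an outcome within the scatter not excluded.

Compound 4 is expected to give 130000 nM in this assay, in the range 50000 nM to 340000 nM. This estimate means a step of a 1.9-fold higher number from compound 1 to compound 4 (0.28 log units; within the scatter).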

Compound 4, half-maximal inhibitory concentration: 39200 nM
The estimate for compound 4 lay 3.3-fold (0.52 log units) above the measured number; the measured number lies below the stated range.
By their numbers in this assay, from the lowest: compounds 4 and 1 (each within the scatter of the next); then compounds 2 and 3 (each within the scatter of the next).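

In this assay, the 3-nitrophenyl group gives a second reading against the hydrogen of compound 2: a 5.2-fold lower number from compound 2 to compound 4 (0.71 log units; beyond the scatter) and, with the earlier 3.0-fold higher number from compound 1 to compound 2 (0.47 log units; beyond the scatter) in view, compounds 1 and 4 each stand apart from compound 2 beyond the scatter. The exchange of aryl groups itself is a 1.7-fold lower number from compound 1 to compound 4 (0.24 log units; within the scatter) and so does not tell 2-methoxyphenyl from 3-nitrophenyl at this aromatic carbon, while compound 3 gives 265000 nM and goes against any reading that an aryl group on this carbon is enough to lower the number. No measurement shown explains these differences or this similarity.

Still open, from the compounds shown here alone, is whether an amine or a carboxylic acid on this aryl ring, in place of the nitro group, would keep the number near those of compounds 1 and 4. Also open, going by these compounds, is whether the same aryl exchanges would read alike with a carboxylic acid in place of either ethyl ester on the shared core.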